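The source may hold more compounds than are shown below. What is called first, only, known or untested is meant among the compounds shown, and "the series" means these compounds.

Compound 3 `COc1cc(N(Cc2ccc(C)cc2)C(=O)CSc2nc3ccccc3s2)cc(OC)c1OC` stands highest of the two numbers recorded in a functional assay on MGC-803 cells (Homo sapiens) for antiproliferative activity, read by MTT assay, with a stated time of 48 h (a higher number here means a weaker inhibitor, a lower number a stronger inhibitor), where compound 3 gives 54200 nM. Compound 2 `COc1ccc(CN(C(=O)CSc2nc3cc(Br)ccc3s2)c2cc(OC)c(OC)c(OC)c2)cc1O` gives 372 nM in this assay. Compound 1 `COc1cc(N(Cc2ccc(F)cc2)C(=O)CSc2nc3ccccc3s2)cc(OC)c1OC` gives only a limit in this assay, > 80000 nM (the limit of > 80000 nM in this assay, at which 1 of the 3 values shown sits). Compound 4 `COc1ccc(CN(C(=O)CSc2nc3ccccc3s2)c2cc(OC)c(OC)c(OC)c2)cc1C(F)(F)F` has not been measured; it differs from compound 3 by 4-methoxy-3-(trifluoromethyl)phenyl in place of 4-methylphenyl on a saturated chain carbon bound to an amide-type nitrogen. Among the measured compounds shown here, the one measured step, an at least 1.4-fold lower number from compound 1 to compound 3 (0.16 log units; that floor lies within the scatter), concerns a change on the same ring but not this one, so it bears only loosely on the new step. Compound 2, with a different aryl and core, shows the gap possible in this assay. The number for compound 4 is expected to fall, giving an estimated 6.8-fold lower number from compound 3 to compound 4 (0.83 log units; beyond the scatter). Compound 4 is thus estimated at 8000 nM, within 800 nM to 60000 nM.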

Compound 4, half-maximal inhibitory concentration: 25200 nM
Estimate against measurement, compound 4: 3.2-fold (0.50 log units) below; the measured number falls inside the stated range.
By their numbers in this assay, from the lowest: compound 2; then compound 4; then compound 3. At a limit, above all of these: compound 1.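

In this assay, 4-methoxy-3-(trifluoromethyl)phenyl in place of 4-methylphenyl gives a 2.2-fold lower number from compound 3 to compound 4 (0.33 log units; beyond the scatter), so this position accepts a substituent with more heavy atoms and a hydrogen-bond acceptor, with a modest gain that the earlier step, within the scatter at its floor, did not show. Against 4-fluorophenyl, the same group gives an at least 3.1-fold lower number from compound 1 to compound 4 (0.50 log units; beyond the scatter), which is only a floor. Compound 1 gives a limit, not a number: the limit of > 80000 nM in this assay, at which 1 of the 4 values shown sits.

The compounds shown do not separate the methoxy from the trifluoromethyl in this step. From the compounds shown here alone, how an amine or a carboxylic acid on this ring would read remains open.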